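The compounds below may be only part of what the source reports. "The series", "measured", "known", "first", "only" and "open" are said of these compounds alone.

Working notes on the series. Compound 1 `Cn1c(=O)c(S(=O)(=O)c2ccc(F)cc2[N+](=O)[O-])cc2cnc(Nc3ccc4[nH]ccc4c3)nc21` gives 1500 nM in a functional assay on DU-145 cells (Homo sapiens) for inhibition, read by trypan blue exclusion, with a stated time of 72 h; on this read-out lower numbers stand for stronger inhibition and higher numbers for weaker inhibition. Compound 2 `Cn1c(=O)c(S(=O)(=O)c2ccc([N+](=O)[O-])cc2F)cc2cnc(Nc3ccc4[nH]ccc4c3)nc21` gives 400 nM in this assay, the step being a 3.8-fold lower number from compound 1 to compound 2 (0.57 log units; beyond the scatter). Compound 3 `Cc1ccc(S(=O)(=O)c2cc3cnc(Nc4ccc5[nH]ccc5c4)nc3n(C)c2=O)cc1` gives 750 nM in this assay; the steps that lead to it are a 2.0-fold lower number from compound 1 to compound 3 (0.30 log units; within the scatter) and a 1.9-fold higher number from compound 2 to compound 3 (0.27 log units; within the scatter). Compound 3 thus stands second highest of the three numbers, with compound 2 nearest and compound 1 furthest, both within the scatter, so no order between these three can be read from the data.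

Compound 4 `Cc1ccc(S(=O)(=O)c2cc3cnc(Nc4cnc5[nH]ccc5c4)nc3n(C)c2=O)cc1` differs from compound 3 in one place: a group of 9 heavy atoms (7 carbon, 2 nitrogen; one five-membered aromatic ring with 1 hetero atom, one six-membered aromatic ring with 1 hetero atom) in place of a group of 9 heavy atoms (8 carbon, 1 nitrogen; one five-membered aromatic ring with 1 hetero atom, one six-membered aromatic ring of carbon only), on a nitrogen on an aromatic ring. Within the data shown here, none of the measured steps touches this part of the molecule; all three concern the group on the sulfonyl sulfur, where the only movement beyond the scatter was a 3.8-fold lower number from compound 1 to compound 2 (0.57 log units; beyond the scatter) and the remaining two stayed within it. Among the measured compounds shown here, no measured step therefore bears directly on the change from compound 3 to compound 4, and no movement beyond the scatter in this assay is expected in either direction. The number for compound 4 is expected to lie close to that of compound 3, at 750 nM with a range of 300 nM to 2000 nM. The step implied by this estimate is expected to be no change at the digits printed from compound 3 to compound 4 (within the scatter).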

Compound 4, half-maximal inhibitory concentration: 25000 nM
For compound 4 the middle estimate is 33-fold (1.52 log units) below the measured one, outside the stated range (above it).
By their numbers in this assay, from the lowest: compounds 2, 3 and 1 (each within the scatter of the next, the first and the last beyond it); then compound 4.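

Working notes, continued. In this assay the group on the nitrogen on an aromatic ring proves far more sensitive than the group on the sulfonyl sulfur: replacing 1H-indol-5-yl with the group of 7 carbon and 2 nitrogen atoms gives a large loss (a 33-fold higher number from compound 3 to compound 4 (1.52 log units; beyond the scatter)), well past the largest step seen at the sulfonyl sulfur (a 3.8-fold lower number from compound 1 to compound 2 (0.57 log units; beyond the scatter)). The two groups match in heavy-atom count, in hydrogen-bond donor count and in having no net charge; they differ in a hetero atom in the six-membered aromatic ring and in the added hydrogen-bond acceptor, so even this small exchange at this place is enough to take most of the activity away. No measurement at hand accounts for the loss.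

Going by these compounds, it remains open whether the same exchange costs as much with 2-fluoro-4-nitrophenyl on the sulfonyl sulfur, since this single pair carries 4-methylphenyl there. Also open, on these data alone, is how far the nitrogen tolerates other groups, such as a phenyl ring bearing an amine or a methoxy group in place of 1H-indol-5-yl.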